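The source may report more compounds than this note shows. Statements on the series, on what has been measured and on what is new or still open speak of the compounds shown alone.

Compound 1 `NS(=O)(=O)c1cc(-c2nnc(CN3CCN(c4ccccc4)CC3)o2)c(Cl)cc1SCc1ccccc1`: 105000 nM
Compound 2 `NS(=O)(=O)c1cc(-c2nnc(Cn3cc(-c4ccccc4)nn3)o2)c(Cl)cc1SCc1ccccc1`: 75000 nM
Compound 3 `COc1ccc(-c2cn(Cc3nnc(-c4cc(S(N)(=O)=O)c(SCc5ccccc5)cc4Cl)o3)nn2)cc1`: 190000 nM

Three compounds sharing one core were tested in a functional assay on HCT-116 cells (Homo sapiens) for cytotoxicity, read by MTT assay, with a stated time of 72 h; on this read-out lower numbers stand for stronger inhibition and higher numbers for weaker inhibition. The smallest of the three numbers belongs to compound 2, though compound 1 lies within the scatter of it, a 1.4-fold lower number from compound 1 to compound 2 (0.15 log units; within the scatter), while compound 3 sits further off, a 2.5-fold higher number from compound 2 to compound 3 (0.40 log units; beyond the scatter). Compound 4 `NS(=O)(=O)c1cc(-c2nnc(/C=C/c3ccccc3)o2)c(Cl)cc1SCc1ccccc1` has not yet been measured. It differs from compound 2 in one place: 2-phenylethenyl in place of (4-phenyl-1H-1,2,3-triazol-1-yl)methyl on an aromatic carbon. Neither measured step resembles this change closely: the step from compound 1 to compound 2 swapped one ring-bearing group for another without leaving the scatter, and the step to compound 3 put a methoxy in place of a hydrogen. With nothing closer to go on, compound 4 is expected to stay near compound 2, a 1.1-fold higher number from compound 2 to compound 4 (0.03 log units; within the scatter), not beyond the scatter. The estimate for compound 4 in this assay is 80000 nM, within 30000 nM to 200000 nM.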

Compound 4, half-maximal inhibitory concentration: 18000 nM
Compound 4: the middle estimate sits 4.4-fold (0.65 log units) above what was measured; the measured number lies below the stated range.
By their numbers in this assay, from the lowest: compound 4; then compounds 2, 1 and 3 (each within the scatter of the next, the first and the last beyond it).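

In this assay, 2-phenylethenyl on this aromatic carbon of the five-membered ring gives a 4.2-fold lower number from compound 2 to compound 4 (0.62 log units; beyond the scatter), so changing this group can move the number beyond the scatter. The earlier swap, a 1.4-fold lower number from compound 1 to compound 2 (0.15 log units; within the scatter), stayed within the scatter, and both of those groups joined the ring through a saturated chain carbon. Nothing measured here explains the difference. The change removes the triazole ring and adds a double bond in one step, so the two cannot be separated. A saturated 2-phenylethyl chain at this position would test the double bond alone.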